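Working notes: from compound 2 to compound 3

The compounds below may be only part of what the source reports. "The series", "measured", "known", "first", "only" and "open" are said of these compounds alone.

Compound 1 `COC(=O)c1c(-c2ccc([N+](=O)[O-])cc2)oc2ccccc2c1=O` gives > 25 ug/mL as a limit of the assay
Compound 2 `O=c1cc(-c2ccc([N+](=O)[O-])cc2)oc2cc(O)ccc12` gives 21.8 ug/mL as a measured number

Both entries come from a functional assay on A549 cells (Homo sapiens) for cytotoxicity, read by MTT assay, with a stated time of 6 days (on this read-out higher numbers stand for an effect only at larger amounts of compound and lower numbers for an effect already at smaller amounts), and neither can be compared with the other as a pair of numbers. The entry for compound 1 is a limit and not a number. Within the data shown here, compound 2 therefore holds the only actual number so far, and it has no measured neighbour to be ranked against.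

Compound 3 `O=c1cc(-c2ccc([N+](=O)[O-])cc2)oc2c(O)c(O)ccc12` is still to be measured. It departs from compound 2 by hydroxy in place of hydrogen on an aromatic carbon in a single place, with hydroxy in place of hydrogen on an aromatic carbon, ortho to a hydroxy group.

Among the measured compounds shown here, no measured step speaks to such a change, so the expectation rests on the structural change alone. A modest move towards lower numbers in this assay is expected, little beyond the usual scatter. The expected size is a 1.6-fold lower number from compound 2 to compound 3 (0.19 log units; within the scatter) on this read-out.

Compound 3 is estimated at 14 ug/mL with an expected range from 6 ug/mL to 25 ug/mL in this read-out.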

Compound 3, concentration for half-maximal effect: 2.56 ug/mL
Beside the measured number, compound 3's estimate is 5.5-fold (0.74 log units) above it; measured number below the stated range.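

In this assay, among these compounds, hydroxy in place of hydrogen on an aromatic carbon gives the first measured step: an 8.5-fold lower number from compound 2 to compound 3 (0.93 log units; beyond the scatter). This step lies beyond the scatter, so this position, ortho to a hydroxy group and part of a fused or bridged system of two rings, is one where a single added hydroxy moves the read-out towards effects at smaller amounts of compound, something the earlier entries could not show without a measured neighbour. Compound 1 holds a limit and not a number, and no step to it can be read: the limit of > 25 ug/mL in this assay, at which 1 of the 3 values shown sits.

Still open, from the compounds shown here alone, is whether the step belongs to hydroxy itself or to its place ortho to a hydroxy group, and whether a methoxy group or an amine on the same aromatic carbon would move the number in the same way. Also open, going by these compounds, is whether the same hydroxy change keeps its size when the nitro group of the shared core gives way to an amine or a carboxylic acid.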